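Swapping Carboxy for Dimethylcarbamoyl

The source may hold more compounds than are shown below. What is called first, only, known or untested is meant among the compounds shown, and "the series" means these compounds.

In a functional assay on L1210 cells (Mus musculus) for inhibition, with a stated time of 48 h (on this read-out lower numbers stand for stronger inhibition and higher numbers for weaker inhibition), compound 1 `COC(=O)C[C@H](NC(=O)OC(C)(C)C)C(=O)N(C)C1(C(=O)NCc2ccccc2)CCN(Cc2ccccc2)CC1` gives a measured number (17000 nM). Compound 2 `CC[C@@H](C)[C@H](NC(=O)OC(C)(C)C)C(=O)N(C1CC1)C1(C(=O)NC(C)(C)C)CCN(Cc2ccccc2)CC1` returns only a limit (> 250000 nM). Compound 3 `CC(C)(C)OC(=O)N[C@@H](CC(=O)O)C(=O)N(Cc1ccccc1)C1(C(=O)NCc2ccccc2)CCN(Cc2ccccc2)CC1` gives (164000 nM), the higher of the two true numbers, and its gap to compound 1 lies beyond the scatter.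

Compound 4 `CN(C)C(=O)C[C@H](NC(=O)OC(C)(C)C)C(=O)N(Cc1ccccc1)C1(C(=O)NCc2ccccc2)CCN(Cc2ccccc2)CC1` differs from compound 3 in one place (dimethylamino in place of hydroxy on a carbonyl carbon): dimethylamino in place of hydroxy on a carbonyl carbon. Going by the values given here, no measured pair isolates this change, so the expectation is loose. Compound 1 also lacks the carboxy group and gives (17000 nM), which suggests a moderate step towards stronger inhibition, beyond the scatter, in this assay. The expected change is (a 2.7-fold lower number from compound 3 to compound 4 (0.44 log units; beyond the scatter)). Compound 4 is estimated at (60000 nM), with an expected range from 15000 nM to 200000 nM.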

Compound 4, half-maximal inhibitory concentration: 76000 nM
For compound 4 the middle estimate is 1.3-fold (0.10 log units) below the measured one; measured number inside the range.
By their numbers in this assay, from the lowest: compound 1; then compound 4; then compound 3. At a limit, above all of these: compound 2.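

Going by these compounds alone, at this carbonyl carbon, whose other neighbour is a saturated chain carbon, dimethylamino in place of hydroxy gives a 2.2-fold lower number from compound 3 to compound 4 (0.33 log units; beyond the scatter) in this assay, the first step in this set that isolates a single place. The carboxy group of compound 3 can therefore give way to dimethylcarbamoyl with a modest gain in inhibition, while the hydrogen-bond donor of the hydroxy leaves. Nothing measured here accounts for this step. As far as these compounds go, whether diethylamino or a plain amino group on the same carbonyl carbon would move the number further remains open, and this single step cannot show whether the change would act alike on other compounds in the set.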